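This account rests on a few compounds, and the source may have more. Where it says the series, first, only, none or still open, it means among the compounds named here.

Working notes on the series. Compound 2 `CC(C)(C)n1ncc(OCc2nnc(-c3cc(F)c(Cl)cc3Cl)s2)c(Cl)c1=O` gives 67.1 ug/mL in a functional assay on the whole organism for inhibition, with Mythimna separata as the target, with a stated time of 5 days; on this read-out higher numbers stand for an effect only at larger amounts of compound and lower numbers for an effect already at smaller amounts. Its number lies within the scatter of compound 1 `CC(C)(C)n1ncc(OCc2nnc(-c3ccc(Cl)cc3Cl)s2)c(Cl)c1=O`, which gives 62.2 ug/mL in this assay, and of compound 3 `Cc1cccc(-c2nnc(COc3cnn(C(C)(C)C)c(=O)c3Cl)o2)c1`, which gives 116 ug/mL. Among the measured compounds shown here, the only measured step, a 1.1-fold higher number from compound 1 to compound 2 (0.03 log units; within the scatter), changes the phenyl substitution and stays within the scatter. Compound 4 `CC(C)(C)n1ncc(OCc2nnc(-c3ccccc3F)s2)c(Cl)c1=O` differs from compound 2 by 2-fluorophenyl in place of 2,4-dichloro-5-fluorophenyl on an aromatic carbon. For the measured compounds named here, no measured step removes chlorine from this phenyl, so the change is not covered; the one phenyl step in hand was flat. In this assay the step of a 1.2-fold higher number from compound 2 to compound 4 (0.08 log units; within the scatter) is therefore expected to be small, direction uncertain, with a wide range. Compound 4 is estimated at 80 ug/mL, from 40 ug/mL to 200 ug/mL.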

Compound 4, half-maximal effective concentration: 121 ug/mL
Compound 4: middle estimate off by 1.5-fold (0.18 log units), on the low side; the measured number falls inside the stated range.
By their numbers in this assay, from the lowest: compounds 1, 2, 3 and 4 (each within the scatter of the next).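

In this assay, among the compounds shown here, this is the first change that takes both chlorines off the phenyl group on this aromatic carbon, and it is read in two steps: a 1.8-fold higher number from compound 2 to compound 4 (0.26 log units; within the scatter) and a 1.9-fold higher number from compound 1 to compound 4 (0.29 log units; within the scatter). Even with 2-fluorophenyl in place of either larger halogenated phenyl, both steps stay within the scatter, so no effect of this change can be separated yet. Nothing available bears on why these steps are this size.

Only halogenated phenyl groups stand at this place among the compounds sharing this core. Going by these compounds, whether an unsubstituted phenyl, a methoxyphenyl or an amine such as morpholine would give a step beyond the scatter remains open.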